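Series notes: aryl substituent swap on the shared core

The source may report more compounds than this note shows. Statements on the series, on what has been measured and on what is new or still open speak of the compounds shown alone.

Compound 2 (`CC(C)[C@@H]1NC(=O)[C@@H](Cc2c[nH]c3c(-c4ccc(C(=O)O)cc4)cccc23)NC(=O)[C@H](CC(=O)O)NC(=O)CNC(=O)[C@H](CCCNC(=N)N)NC1=O`) stands lowest of the two numbers measured in an assay on a protein complex for binding affinity to integrin alpha-5/beta-1 (Homo sapiens), read by ELISA, with a stated time of 1 h (on this read-out higher numbers stand for weaker inhibition and lower numbers for stronger inhibition), giving 22 nM; compound 1 (`CC(C)[C@@H]1NC(=O)[C@@H](Cc2c[nH]c3c(-c4cccc(N)c4)cccc23)NC(=O)[C@H](CC(=O)O)NC(=O)CNC(=O)[C@H](CCCNC(=N)N)NC1=O`) gives 610 nM. Among the measured compounds shown here, the one measured step, a 28-fold lower number from compound 1 to compound 2 (1.44 log units; beyond the scatter), brought 4-carboxyphenyl in place of 3-aminophenyl. Compound 3 (`COc1ccc(-c2cccc3c(C[C@H]4NC(=O)[C@H](CC(=O)O)NC(=O)CNC(=O)[C@H](CCCNC(=N)N)NC(=O)[C@H](C(C)C)NC4=O)c[nH]c23)cc1`) is not yet measured; it differs from compound 2 by methoxy in place of carboxy on an aromatic carbon, on an aromatic carbon para to a large group. For the measured compounds named here, only that measured step bears on this change: there carboxy entered, here it leaves. A step toward weaker inhibition is therefore expected, about a 14-fold higher number from compound 2 to compound 3 (1.13 log units; beyond the scatter). Compound 3 is estimated at 300 nM, with a range from 60 nM to 1500 nM.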

Compound 3, half-maximal inhibitory concentration: 66 nM
Beside the measured number, compound 3's estimate is 4.5-fold (0.66 log units) above it; the range from low to high includes it.
By their numbers in this assay, from the lowest: compound 2; then compound 3; then compound 1.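

In this assay, the carboxy is not needed for a low number at this position: methoxy in its place gives a 3.0-fold higher number from compound 2 to compound 3 (0.48 log units; beyond the scatter). The 4-methoxyphenyl still improves on the 3-aminophenyl, with a 9.2-fold lower number from compound 1 to compound 3 (0.97 log units; beyond the scatter), so a substantial part of the gain holds without the carboxy. Nothing measured here explains either step.

Still open, going by these compounds, is how much of the gain from compound 1 belongs to the substituent's place and how much to the group itself. Also open, on these data alone, is what an amine or a hydroxyl would give para to a large group.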